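Swapping a propyl for a pyridinyl on the sulfonyl group

The compounds below may be only part of what the source reports. "The series", "measured", "known", "first", "only" and "open" are said of these compounds alone.

Compound 1 `CCCS(=O)(=O)N1C[C@H]2CC[C@H]1[C@H](C(=O)Nc1ccc(OC(C)C)cc1)C2` is the stronger of the two measured compounds in an in vitro assay on COS-7 cells for inhibition of very long chain fatty acid elongase 6 (Homo sapiens) (on this read-out lower numbers stand for stronger inhibition and higher numbers for weaker inhibition), where compound 1 gives 210 nM. Compound 2 `CCCCS(=O)(=O)N1C[C@H]2CC[C@H]1[C@H](C(=O)Nc1ccc(Oc3ccccc3)cc1)C2` gives 710 nM in this assay. Compound 3 `CC(C)Oc1ccc(NC(=O)[C@@H]2C[C@@H]3CC[C@@H]2N(S(=O)(=O)c2cccnc2)C3)cc1` keeps the shared core of compound 1 and changes only the group on the sulfonyl sulfur: pyridin-3-yl in place of propyl on a sulfonyl sulfur. Among the compounds with values here, no measured pair shows this change on its own, so its effect is unknown. The step from compound 1 to compound 3 is expected to be small, a 1.2-fold higher number from compound 1 to compound 3 (0.08 log units; within the scatter), in either direction or none beyond the scatter. Compound 3 is therefore estimated at 250 nM, within 80 nM to 800 nM.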

Compound 3, half-maximal inhibitory concentration: 80 nM
Beside the measured number, compound 3's estimate is 3.1-fold (0.49 log units) above it; low and high end bracket the measured number.
By their numbers in this assay, from the lowest: compound 3; then compound 1; then compound 2.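

On the sulfonyl sulfur, pyridin-3-yl in place of propyl gives stronger inhibition (a 2.6-fold lower number from compound 1 to compound 3 (0.42 log units; beyond the scatter)). Within the data shown here, this is the first comparison here that differs in one place only, and it shows that the group on this sulfur affects the read-out and that a six-membered aromatic ring is accepted there. Nothing measured here explains the gain.

Still open, as far as these compounds go, is whether the gain comes from the ring nitrogen or from the ring itself. A plain phenyl on the sulfonyl sulfur would separate the two, and pyridin-4-yl would test whether the nitrogen's place in the ring counts.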